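From Benzofuran to Furan on the Shared Core

A few compounds are considered here, and "the series" means these few. Any claim that something is new, unique, unknown or untested is made for them only; others in the source may bear on it.

Three measured analogues share one core and differ only in the group on one aromatic carbon. In a functional assay on HCT-116 cells (Homo sapiens), read by MTT assay, with a stated time of 72 h (a lower number here means a stronger inhibitor, a higher number a weaker inhibitor), compound 1 `COc1ncnc2c1c(-c1ccccc1)cn2[C@@H]1O[C@H](CO)[C@@H](O)[C@H]1O` gives > 20000 nM, which is a limit of the assay and not a number. Compound 2 `COc1ncnc2c1c(I)cn2[C@@H]1O[C@H](CO)[C@@H](O)[C@H]1O` gives > 20000 nM, again only a limit. Going by the values given here, compound 3 `COc1ncnc2c1c(-c1cc3ccccc3o1)cn2[C@@H]1O[C@H](CO)[C@@H](O)[C@H]1O` is the sole analogue with a real number, 13800 nM, and stands as the one measurable point against (the limit of > 20000 nM in this assay, at which 2 of the 3 values shown sit). The steps of an at least 1.4-fold lower number from compound 1 to compound 3 (0.16 log units; that floor lies within the scatter) and an at least 1.4-fold lower number from compound 2 to compound 3 (0.16 log units; that floor lies within the scatter) are therefore floors, not true sizes. Compound 4 `COc1ncnc2c1c(-c1ccco1)cn2[C@@H]1O[C@H](CO)[C@@H](O)[C@H]1O` carries furan-2-yl in place of 1-benzofuran-2-yl on an aromatic carbon. This removes much of what separates compound 3 from compound 1, so the expected step of a 2.2-fold higher number from compound 3 to compound 4 (0.34 log units; beyond the scatter) points toward a weaker compound. Compound 4 is estimated at 30000 nM, with a range from 8000 nM to 100000 nM, and may well return only a limit.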

Compound 4, half-maximal inhibitory concentration: 40 nM
Estimate against measurement, compound 4: 750-fold (2.88 log units) above, and the stated range ends above it.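

In this assay, going by these compounds alone, this one position proves far more sensitive than the earlier compounds could show, with furan-2-yl in place of 1-benzofuran-2-yl giving a large gain (a 350-fold lower number from compound 3 to compound 4 (2.54 log units; beyond the scatter)). The five-membered ring alone cannot account for the strength, since compound 3 carries that ring too, along with a six-membered aromatic ring, and stays weak. The other two steps (an at least 500-fold lower number from compound 2 to compound 4 (2.69 log units; beyond the scatter); an at least 500-fold lower number from compound 1 to compound 4 (2.69 log units; beyond the scatter)) are floors, not true sizes, as compound 1 and compound 2 gave only limits: (the limit of > 20000 nM in this assay, at which 2 of the 4 values shown sit). As far as these compounds go, whether thiophen-2-yl or an amine at this position would keep the strength of compound 4 remains open.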